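The source may report more compounds than this note shows. Statements on the series, on what has been measured and on what is new or still open speak of the compounds shown alone.

Compound 1, `Cc1ccc(NC2=C(Nc3ccc(C)cc3)C(=O)c3ccccc3C2=O)cc1` — > 450000 nM
Compound 2, `O=C1C(Nc2ccc(C(F)(F)F)cc2)=C(Nc2ccc(C(F)(F)F)cc2)C(=O)c2ccccc21` — 276000 nM
Compound 3, `Cc1ccccc1NC1=C(Nc2ccccc2C)C(=O)c2ccccc2C1=O` — > 450000 nM

In an ADME assay on L6 cells (Rattus norvegicus) for cytotoxicity, read by sulforhodamine B assay, with a stated time of 72 h (on this read-out higher numbers stand for weaker inhibition and lower numbers for stronger inhibition), compound 1 gives > 450000 nM, which is a limit of the assay rather than a number. Compound 3 likewise gives a limit, > 450000 nM. Within the data shown here, compound 2 gives 276000 nM, the one measured number in the set. Compound 1 therefore sits at the limit of > 450000 nM in this assay, at which 2 of the 3 values shown sit. Compound 4, `Cc1ccc(NC2=C(Nc3ccc(C)cc3)C(=O)c3c(cccc3[N+](=O)[O-])C2=O)cc1`, differs from compound 1 by nitro in place of hydrogen on an aromatic carbon, that is, a nitro in place of hydrogen on an aromatic carbon. Among the measured compounds shown here, no measured pair in the set carries this change, so no measured step sets its size. The step expected in this assay is small and leaning toward stronger inhibition, with a fair chance that only a limit is reported again; the estimate implies an at least 1.2-fold lower number from compound 1 to compound 4 (0.10 log units; that floor lies within the scatter). Compound 4 is expected to give about 350000 nM, in the range 120000 nM to 1000000 nM.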

Compound 4, half-maximal inhibitory concentration: 172000 nM
Beside the measured number, compound 4's estimate is 2.0-fold (0.31 log units) above it, within the range that was stated.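

In this assay, a change on the aromatic ring in the fused system of the shared core now shows up: nitro in place of hydrogen gives an at least 2.6-fold lower number from compound 1 to compound 4 (0.41 log units; beyond the scatter). The earlier compounds shown here all carry only hydrogen on this ring, so they gave no reading of this place. The step is a floor rather than a size, because compound 1 stands at a limit: the limit of > 450000 nM in this assay, at which 2 of the 4 values shown sit.

Going by these compounds, whether an amine or a carboxylic acid on the same aromatic carbon would shift the number as nitro does stays open. So does whether nitro would give a similar step on compound 2 or compound 3.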